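The compounds below may be only part of what the source reports. "The series", "measured", "known", "first", "only" and "open" are said of these compounds alone.

Measured compounds and their values:
- compound 1 `Cc1ccc(S(=O)(=O)NCc2ccc(CNC(=O)c3ccc(F)cn3)cc2)cc1`: 1000 nM
- compound 2 `O=C(NCc1ccc(CNS(=O)(=O)c2cccc(F)c2)cc1)c1ccc(F)cc1`: 1000 nM
- compound 3 `O=C(NCc1ccc(CNS(=O)(=O)c2ccc(-c3ccc(F)cc3)cc2)cc1)c1ccc(F)cc1`: 100 nM

In an assay on MDA-MB-231 cells for binding affinity to C-X-C chemokine receptor type 4 (Homo sapiens), read by fluorescence and microscopy, with stated times of 10 min and 30 min (on this read-out higher numbers stand for an effect only at larger amounts of compound and lower numbers for an effect already at smaller amounts), compound 1 stands level with compound 2 at the digits given, within the scatter, and the two together hold the highest numbers of the three. Compound 3 shows a clearly lower number, beyond the scatter. Compound 4 `Cc1ccc(S(=O)(=O)NCc2ccc(CNC(=O)c3ccc(F)nc3)cc2)cc1` is not yet measured; it keeps the same atoms as compound 1, joined differently: 6-fluoropyridin-3-yl in place of 5-fluoropyridin-2-yl on a carbonyl carbon. Going by the values given here, no measured pair shows this kind of change, so the step is expected to stay within the scatter, with no clear direction. For compound 4 the estimate is 1200 nM, within 400 nM to 4000 nM, which is expected to mean a 1.2-fold higher number from compound 1 to compound 4 (0.08 log units; within the scatter).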

Compound 4, effective concentration (reported as EC, without a stated level of effect): > 1000 nM
Compound 4: a limit, no number; the forecaster's own chance of this, stated with the estimate: 5%; the middle value is on the limit's open side.
By their numbers in this assay, from the lowest: compound 3; then compounds 1 and 2 (each within the scatter of the next).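

In this assay compound 4 gives > 1000 nM, which is a limit of the assay and not a number. Placing 6-fluoropyridin-3-yl in place of 5-fluoropyridin-2-yl on a carbonyl carbon, with the same atoms joined differently, gives a number no lower from compound 1 to compound 4 (the limit leaves the size open). This first single-place comparison therefore shows no gain from this rearrangement, although the size of the step cannot be read.

The compounds shown leave open how a piperidine or a morpholine on this carbonyl carbon would read in this assay. They also leave open whether a carboxylic acid there would give a lower number.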